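Swapping the ether oxygen for sulfur on a shared core

The source may report more compounds than this note shows. Statements on the series, on what has been measured and on what is new or still open speak of the compounds shown alone.

Measured so far:
Compound 1, `Nc1cc(N)c2nc(-c3ccccc3)c(Oc3ccc(Cl)c(Cl)c3)nc2c1`: 14100 nM
Compound 2, `CCOC(=O)[C@H](CCC(=O)O)NC(=O)c1ccc(CNc2nc3cc(N)cc(N)c3nc2-c2ccccc2)cc1`: 45700 nM
Compound 3, `COc1ccc(CNc2nc3cc(N)cc(N)c3nc2-c2ccccc2)cc1OC`: 4270 nM

The three compounds were tested in a functional assay on M14 cells (Homo sapiens) for inhibition, read by sulforhodamine B assay, with a stated time of 48 h; on this read-out higher numbers stand for weaker inhibition of growth and lower numbers for stronger inhibition of growth. Compound 1 sits in the middle of the three numbers: compound 2 gives the higher value and compound 3 the lower one, and both gaps from compound 1 lie beyond the usual scatter of repeated measurements.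

Compound 4, `Nc1cc(N)c2nc(-c3ccccc3)c(Sc3ccc(Cl)c(Cl)c3)nc2c1`, has not been measured. It differs from compound 1 in one place: (3,4-dichlorophenyl)sulfanyl in place of 3,4-dichlorophenoxy on an aromatic carbon. Going by the values given here, no pair of measured compounds shows this kind of change, so its effect is not known here. The step is expected to be small, probably not beyond the scatter, and is estimated as a 1.4-fold lower number from compound 1 to compound 4 (0.15 log units; within the scatter). Compound 4 is therefore expected to give about 10000 nM, within a range from 4000 nM to 30000 nM.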

Compound 4, concentration for 50% growth inhibition: 32400 nM
The estimate for compound 4 lay 3.2-fold (0.51 log units) below the measured number; the whole stated range lies below it.
By their numbers in this assay, from the lowest: compound 3; then compound 1; then compounds 4 and 2 (each within the scatter of the next).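

In this assay, this position responds to a change of a single linking atom: replacing 3,4-dichlorophenoxy with (3,4-dichlorophenyl)sulfanyl gives a 2.3-fold higher number from compound 1 to compound 4 (0.36 log units; beyond the scatter), meaning weaker inhibition of growth. The heavy-atom, donor and acceptor counts of the two groups are the same, so those counts alone do not predict this step. Nothing available here explains why the sulfur link gives the weaker result. Still open, from the compounds shown here alone, is how a methylene or sulfonyl link would behave at this position, and whether the step would persist with an unsubstituted phenyl ring in place of the dichlorophenyl ring.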